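The compounds below may be only part of what the source reports. "The series", "measured", "known", "first", "only" and "open" are said of these compounds alone.

Compound 2 `COC(=O)[C@@H](CC(C)C)NC(=O)Cn1cc(C2=C(c3c[nH]c4ccccc34)C(=O)N(C)C2=O)c2ccccc21` gives 37400 nM in a functional assay on MCF7 cells (Homo sapiens) for cytotoxicity, read by MTT assay, with a stated time of 24 h (on this read-out higher numbers stand for weaker inhibition and lower numbers for stronger inhibition), the highest of the two numbers available, its nearest neighbour being compound 1 `COC(=O)[C@H](NC(=O)Cn1cc(C2=C(c3c[nH]c4ccccc34)C(=O)N(C)C2=O)c2ccccc21)C(C)C` with 16000 nM. For the measured compounds named here, the one measured step in this small set is a 2.3-fold higher number from compound 1 to compound 2 (0.37 log units; beyond the scatter), a modest move in the direction of weaker inhibition on changing the chain at the amide-bearing carbon.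

Compound 3 `COC(=O)C[C@@H](NC(=O)Cn1cc(C2=C(c3c[nH]c4ccccc34)C(=O)N(C)C2=O)c2ccccc21)C(=O)OC` is not yet measured. Relative to compound 2 the change is methoxycarbonyl in place of isopropyl on a saturated chain carbon, two bonds along the chain from an amide-type nitrogen and a carbonyl carbon; read one bond further out, isobutyl becomes (methoxycarbonyl)methyl. Going by the values given here, no measured step covers a change of this kind: the only comparison on record swaps one hydrocarbon chain for another, and nothing shows how an ester at that position behaves. The size of the measured step suggests that changes at this carbon shift the number only modestly. The step from compound 2 to compound 3 is therefore expected to be small, a 1.2-fold lower number from compound 2 to compound 3 (0.10 log units; within the scatter), in no firm direction and possibly within the scatter. For compound 3 the expected value in this assay is 30000 nM, with a range from 12000 nM to 80000 nM.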

Compound 3, half-maximal inhibitory concentration: 25800 nM
Estimate against measurement, compound 3: 1.2-fold (0.07 log units) above, within the range that was stated.
By their numbers in this assay, from the lowest: compounds 1, 3 and 2 (each within the scatter of the next, the first and the last beyond it).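

In this assay the first chain carrying methoxycarbonyl at this carbon gives a 1.4-fold lower number from compound 2 to compound 3 (0.16 log units; within the scatter) and a 1.6-fold higher number from compound 1 to compound 3 (0.21 log units; within the scatter), so (methoxycarbonyl)methyl cannot be told apart from either isobutyl or isopropyl. For the compounds shown here, the two hydrocarbon chains remain the only pair separated beyond the scatter, with a 2.3-fold higher number from compound 1 to compound 2 (0.37 log units; beyond the scatter), and compound 3 fills the gap between their values without being distinguishable from either, so the position accepts an ester-bearing chain in place of a purely hydrocarbon one with no resolvable change in this small set. No measurement on hand bears on why these numbers fall as they do.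

The compounds shown leave open whether the small spread holds for a free carboxylic acid in place of the methyl ester, for an amine on the chain, or for a longer chain or a phenyl-bearing one such as benzyl at this carbon. From the compounds shown here alone, it also remains open how the opposite configuration at this carbon would read, and whether the near-equality of compound 2 and compound 3 carries over to any read-out other than this assay.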